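The source may hold more compounds than are shown below. What is called first, only, known or untested is meant among the compounds shown, and "the series" means these compounds.

Compound 2 `Nc1cccc2c(-c3cccc(NC(=O)c4ccc(Cl)c(C(F)(F)F)c4)c3)ccnc12` gives 1400 nM in a functional assay on A375P cells (Homo sapiens) for antiproliferative activity, read by MTT assay, with a stated time of 48 h (a higher number here means a weaker inhibitor, a lower number a stronger inhibitor), the lower of the two numbers in hand; compound 1 `Nc1cccc2c(-c3cccc(NC(=O)c4cccc(C(F)(F)F)c4)c3)ccnc12` gives 7900 nM. Going by the values given here, the single measured step, a 5.6-fold lower number from compound 1 to compound 2 (0.75 log units; beyond the scatter), came with chloro in place of hydrogen on an aromatic carbon. Compound 3 `Nc1cccc2c(-c3cccc(NC(=O)c4ccc(F)c(C(F)(F)F)c4)c3)ccnc12` differs from compound 2 by fluoro in place of chloro on an aromatic carbon. Among the compounds with values here, no measured step swaps one halogen for another, so that step gives only a rough bound: a partial retreat toward the number of compound 1 is expected. The expected value for compound 3 is 3000 nM, within 1400 nM to 7000 nM. This estimate corresponds to a step of a 2.1-fold higher number from compound 2 to compound 3 (0.33 log units; beyond the scatter).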

Compound 3, half-maximal inhibitory concentration: 10400 nM
Compound 3: middle estimate off by 3.5-fold (0.54 log units), on the low side, and the stated range ends below it.
By their numbers in this assay, from the lowest: compound 2; then compounds 1 and 3 (each within the scatter of the next).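

At this position the gain seen with chloro does not carry over to fluoro: in this assay the swap gives a 7.4-fold higher number from compound 2 to compound 3 (0.87 log units; beyond the scatter), and fluoro in place of hydrogen gives a 1.3-fold higher number from compound 1 to compound 3 (0.12 log units; within the scatter), so compound 3 and compound 1 cannot be told apart. A halogen as such is therefore not enough here; of the three compounds, only compound 2, with chloro, stands apart. Nothing on hand explains the difference between the two halogens. As far as these compounds go, whether bromo or methyl at this position would match chloro stays open, as does whether the chloro gain holds without the trifluoromethyl group.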